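Trading an Ethylcarbamoyl for a Methyl on the Core

The source may report more compounds than this note shows. Statements on the series, on what has been measured and on what is new or still open speak of the compounds shown alone.

Of the compounds shown here, three sharing one core have been measured in an assay on Sf9 cells for inhibition of mitogen-activated protein kinase kinase kinase 14 (Homo sapiens), read by ADP-Glo, with a stated time of 60 min; on this read-out higher numbers stand for weaker inhibition and lower numbers for stronger inhibition. Compound 1 `CCCC(=O)n1nc(C)c(-c2ccc(Cl)c(Cl)c2)c1N` gives in this assay only a limit of the assay, > 100000 nM. Compound 2 `Cc1nn(C(=O)C2CCCC2)c(N)c1-c1ccc(Cl)c(Cl)c1` gives 41000 nM in this assay. Compound 3 `CCNC(=O)n1nc(C)c(-c2ccc(Cl)c(Cl)c2)c1N` likewise reaches only a limit of the assay, > 100000 nM. So compound 3 stands at the weak end of what has been measured, sharing its limit with compound 1 (the limit of > 100000 nM in this assay, at which 2 of the 3 values shown sit), while compound 2 alone returns a number.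

The measured steps are these: an at least 2.4-fold lower number from compound 1 to compound 2 (0.38 log units; beyond the scatter); an at least 2.4-fold higher number from compound 2 to compound 3 (0.38 log units; beyond the scatter); a step that the two limits leave unreadable from compound 1 to compound 3. Each of them swaps the group on a carbonyl carbon and keeps that carbonyl in place.

Compound 4 `Cc1nn(C)c(N)c1-c1ccc(Cl)c(Cl)c1` differs from compound 3 in another way: methyl in place of ethylcarbamoyl on an aromatic nitrogen. Here the carbonyl itself leaves. Going by the values given here, none of the measured steps removes the carbonyl, so none bears directly on this change; they show only that variation around this carbonyl has moved the read-out between a limit and a number. The direction of the coming step cannot be read from them. Compound 4 is therefore estimated at 50000 nM in this assay, within 5000 nM to 200000 nM. The expected step is an at least 2.0-fold lower number from compound 3 to compound 4 (0.30 log units; that floor lies within the scatter), and a limit may well come back again.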

Compound 4, half-maximal inhibitory concentration: > 100000 nM
Compound 4: a limit, no number (the forecaster's own chance of this, stated with the estimate: 50%); middle value at least 2.0-fold (0.30 log units) from the limit.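

In this assay compound 4 gives > 100000 nM, which is a limit of the assay and not a number. Putting methyl in place of cyclopentylcarbonyl on the aromatic nitrogen gives an at least 2.4-fold higher number from compound 2 to compound 4 (0.38 log units; beyond the scatter), so this smaller group, which carries no carbonyl, does not keep the one measurable inhibition in the set, and of the four groups shown on this nitrogen only cyclopentylcarbonyl returns a number. The steps to compound 4 from compound 1 and from compound 3 cannot be read, because both ends of each step are limits: the limit of > 100000 nM in this assay, at which 3 of the 4 values shown sit.

As far as these compounds go, whether methyl truly differs from ethylcarbamoyl or propylcarbonyl therefore stays open, since all three may lie anywhere past the same limit. Also open, from the compounds shown here alone, is whether the cyclopentyl ring needs its carbonyl, which a cyclopentyl group set directly on the aromatic nitrogen would test, and whether a cyclohexylcarbonyl or benzoyl group in the same place would bring the number lower than cyclopentylcarbonyl does.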